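From Nitro to Iodo in a Flat Series

A few compounds are considered here, and "the series" means these few. Any claim that something is new, unique, unknown or untested is made for them only; others in the source may bear on it.

Of the compounds shown here, three that share one core have been tested in a functional assay on MCF7 cells (Homo sapiens) for antiproliferative activity, read by MTT assay, with a stated time of 48 h; a lower number here means a stronger inhibitor, a higher number a weaker inhibitor. They differ only in a single substituted phenyl group. Compound 1 (`COc1ccc2nc(NC(c3cn(-c4ccccc4)nc3-c3ccc(Cl)cc3)c3c(O)ccc4ccccc34)sc2c1`), with 4-chlorophenyl, gives 23700 nM. Compound 2 (`COc1ccc(-c2nn(-c3ccccc3)cc2C(Nc2nc3ccc(OC)cc3s2)c2c(O)ccc3ccccc23)cc1`), with 4-methoxyphenyl, gives 41800 nM. Compound 3 (`COc1ccc2nc(NC(c3cn(-c4ccccc4)nc3-c3cccc([N+](=O)[O-])c3)c3c(O)ccc4ccccc34)sc2c1`), with 3-nitrophenyl, gives 26800 nM, a number that cannot be told apart from the other two.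

Compound 4 (`COc1ccc2nc(NC(c3cn(-c4ccccc4)nc3-c3cccc(I)c3)c3c(O)ccc4ccccc34)sc2c1`) carries 3-iodophenyl instead, with iodo in place of nitro on an aromatic carbon, meta to a large group (iodo in place of nitro on an aromatic carbon). Within the data shown here, no measured pair makes this exact exchange, so the evidence is indirect. Among the measured compounds shown here, the steps that bear on it are the other exchanges on the same phenyl group: a 1.1-fold higher number from compound 1 to compound 3 (0.05 log units; within the scatter), a 1.6-fold lower number from compound 2 to compound 3 (0.19 log units; within the scatter) and a 1.8-fold higher number from compound 1 to compound 2 (0.25 log units; within the scatter). Each of these stayed within the scatter, and together they favour no direction. A step beyond the scatter is therefore not expected in this assay. The expected step is a 1.0-fold higher number from compound 3 to compound 4 (0.02 log units; within the scatter), which is no real change. Compound 4 is estimated to give 28000 nM, with an expected range from 14000 nM to 52000 nM.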

Compound 4, half-maximal inhibitory concentration: 20000 nM
For compound 4 the middle estimate is 1.4-fold (0.15 log units) above the measured one; measured number inside the range.
By their numbers in this assay, from the lowest: compounds 4, 1, 3 and 2 (each within the scatter of the next, the first and the last beyond it).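

Replacing nitro with iodo removes the hydrogen-bond acceptors of the nitro group at this place on the phenyl ring, yet in this assay this exchange gives only a 1.3-fold lower number from compound 3 to compound 4 (0.13 log units; within the scatter), and the exchange of the whole aryl group gives a 1.2-fold lower number from compound 1 to compound 4 (0.07 log units; within the scatter), so neither step can be told apart from repeat-measurement noise. Among these compounds, the one new finding is a 2.1-fold lower number from compound 2 to compound 4 (0.32 log units; beyond the scatter), the first step in this set to pass the scatter, though it is modest and separates only the two compounds at the ends of the series, while compound 1 and compound 3 remain within the scatter of compound 4. Nothing measured here explains these numbers or links them to any property of the groups.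

As far as these compounds go, all four compounds carry a halogen, a methoxy or a nitro group on this phenyl ring, so it remains open whether an amine, a carboxylic acid or a longer chain there would produce a larger step. From the compounds shown here alone, it is equally open whether a change elsewhere on the shared core, rather than on this ring, would move the number further in this assay.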